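The source may report more compounds than this note shows. Statements on the series, on what has been measured and on what is new or still open speak of the compounds shown alone.

Measured compounds:
- compound 1, `CN1CCN(c2ccc(Nc3ncc4nc(Nc5ccc(F)cc5)n([C@H]5CCCN(S(=O)(=O)C6CC6)C5)c4n3)cc2)CC1`: 1340 nM
- compound 2, `CN1CCN(c2ccc(Nc3ncc4nc(Nc5ccc(F)cc5)n([C@@H]5CCN(C(=O)OC(C)(C)C)C5)c4n3)cc2)CC1`: "not determined" (no result reported)
- compound 3, `CN1CCN(c2ccc(Nc3ncc4nc(Nc5ccccc5)n([C@H]5CCN(S(=O)(=O)C6CC6)C5)c4n3)cc2)CC1`: 1670 nM

The account follows the change from compound 1 to compound 4. In a functional assay on A-431 cells (Homo sapiens) for antiproliferative activity, read by MTT assay, with a stated time of 72 h (a lower number here means a stronger inhibitor, a higher number a weaker inhibitor), compound 1 gives 1340 nM, the lowest of the two numbers available, though compound 3, which gives 1670 nM in this assay, stands within the scatter of it, so no order between the two can be claimed. Compound 2 has no number in this assay.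

Compound 4, `CN1CCN(c2ccc(Nc3ncc4nc(Nc5ccc(F)cc5)n([C@H]5CCN(S(=O)(=O)C6CC6)C5)c4n3)cc2)CC1`, differs from compound 1 in one place: 1-(cyclopropylsulfonyl)pyrrolidin-3-yl in place of 1-(cyclopropylsulfonyl)piperidin-3-yl on an aromatic nitrogen. Compound 3 carries the same 1-(cyclopropylsulfonyl)pyrrolidin-3-yl group, and its value in this assay sits close to that of compound 1. Among the compounds with values here, with no measured step between compounds that differ only in this ring, the change is expected to bring no shift beyond the scatter, in either direction. Compound 4 is therefore estimated at 1400 nM in this assay, within 600 nM to 3200 nM, a step of a 1.0-fold higher number from compound 1 to compound 4 (0.02 log units; within the scatter) that is expected to stay within the usual variation.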

Compound 4, half-maximal inhibitory concentration: 1670 nM
For compound 4 the middle estimate is 1.2-fold (0.08 log units) below the measured one; the range from low to high includes it.
By their numbers in this assay, from the lowest: compounds 1, 3 and 4 (each within the scatter of the next).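

In this assay, within the data shown here, the first measured step for this ring change, 1-(cyclopropylsulfonyl)pyrrolidin-3-yl in place of 1-(cyclopropylsulfonyl)piperidin-3-yl on the aromatic nitrogen, stays within the scatter (a 1.2-fold higher number from compound 1 to compound 4 (0.10 log units; within the scatter)), so neither ring size can be placed ahead of the other at this position. Among these compounds, compound 4 also gives the first direct reading of fluoro in place of hydrogen on an aromatic carbon, and that step too shows no difference (no change at the digits printed from compound 3 to compound 4 (within the scatter)). Nothing in the data shown speaks to the reason for either result.

Compound 2, with its tert-butoxycarbonyl group, offers no number for comparison. As far as these compounds go, what a free amine or a methylsulfonyl group would give in place of cyclopropylsulfonyl stays open, as does whether any change at this position can move the number beyond the scatter.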